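Demethylation on the core oxygen and urate transporter inhibition

This account rests on a few compounds, and the source may have more. Where it says the series, first, only, none or still open, it means among the compounds named here.

Compound 1 `CCc1oc2cc(OC)ccc2c1C(=O)c1ccc(OC)cc1` and compound 2 `CCc1cc2c(C(=O)c3ccc(OC)cc3)ccc(OC)c2o1` are built from the same atoms joined differently; how their two cores differ is not broken down here. In an assay for inhibition of solute carrier family 22 member 12 (Homo sapiens), read by scintillation counting, with a stated time of 60 min, tested at 50 uM (a higher number here means more inhibition at the concentration tested (going by the name of the read-out), a lower number less inhibition), compound 1 gives 6.2%, and compound 2 gives 7.4%, the two lying within the scatter of each other. Compound 3 `CCc1oc2cc(O)ccc2c1C(=O)c1ccc(OC)cc1` carries hydrogen in place of methyl on an oxygen on an aromatic ring, and in this assay compound 3 gives 48.3%; the step of a number 42.1 percentage points higher from compound 1 to compound 3 (beyond the scatter) is a large one.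

Compound 4 `CCc1cc2c(C(=O)c3ccc(OC)cc3)ccc(O)c2o1` stands to compound 2 as compound 3 stands to compound 1, through (hydrogen in place of methyl on an oxygen on an aromatic ring), at a place described in the same words for both pairs. Because compound 1 to compound 3 showed a number 42.1 percentage points higher from compound 1 to compound 3 (beyond the scatter) in this assay, the same change on compound 2 is expected to give a step of similar size, a number 39.6 percentage points higher from compound 2 to compound 4 (beyond the scatter). On that basis compound 4 is estimated to reach 47% in this assay, with a plausible range from 25% to 65%, resting on a single measured precedent.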

Compound 4, a percentage reported as inhibition, at one concentration (the size of the read-out at that concentration, not a potency): 0.8%
Estimate against measurement, compound 4: 46.2 percentage points above; measured number outside the range, below it.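

In this assay, methoxy to hydroxy on the core of compound 2 gives a number 6.6 percentage points lower from compound 2 to compound 4 (within the scatter), so the large rise seen on the core of compound 1 does not carry over to this second core. Among these compounds, the same change therefore cannot be read across these two cores as one transferable effect, as the two steps set side by side show: the same change on two cores in this assay, a number 42.1 percentage points higher (beyond the scatter) from compound 1 to compound 3 and a number 6.6 percentage points lower (within the scatter) from compound 2 to compound 4, 48.7 percentage points apart, beyond the scatter of two such steps This does not show which feature of the two cores separates the outcomes, and with only one pair on each core it gives no rule for predicting the change on any further core.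

The compounds shown leave open how the two cores would respond if that oxygen carried something other than methyl or hydrogen, such as a longer chain, or if an amine or a carboxylic acid stood there instead. They also leave open whether the other methoxy group, present in all of them, would respond to demethylation in the same way on either core.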